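A few compounds are considered here, and "the series" means these few. Any claim that something is new, unique, unknown or untested is made for them only; others in the source may bear on it.

Measured compounds:
- Compound 1 `O=C(/C=C/c1coc2cc(O)ccc2c1=O)NCc1ccc(F)cc1`. In a functional assay on A549 cells (Homo sapiens) for inhibition, read by MTT assay, with a stated time of 48 h (on this read-out higher numbers stand for weaker inhibition and lower numbers for stronger inhibition), compound 1 gives > 100000 nM, which is a limit of the assay rather than a number (the limit of > 100000 nM in this assay, at which 1 of the 3 values shown sits).
- Compound 2 `COc1ccc2c(=O)c(/C=C/C(=O)Nc3cc(C)ccc3C)coc2c1`. Compound 2 gives 15500 nM.
- Compound 3 `Cc1ccc(CNC(=O)/C=C/c2coc3cc(O)ccc3c2=O)cc1`. Compound 3 gives 17400 nM.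

Among the two numbers, compound 2 holds the lower one, but compound 3 lies within the scatter of it, so the two cannot be told apart. Going by the values given here, the one step resolved here is an at least 5.7-fold lower number from compound 1 to compound 3 (0.75 log units; beyond the scatter), a methyl in place of fluoro on an aromatic carbon. Compound 4 `COc1ccc2c(=O)c(/C=C/C(=O)Nc3ccccc3OC)coc2c1` differs from compound 2 by 2-methoxyphenyl in place of 2,5-dimethylphenyl on an amide-type nitrogen. Among the compounds with values here, no measured step swaps substituents on this anilide ring, so the step gives no direct guide. Compound 4 is therefore expected to show a 1.0-fold higher number from compound 2 to compound 4 (0.01 log units; within the scatter), a change not beyond the scatter, with an estimate of 16000 nM (range 5000 nM to 50000 nM).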

Compound 4, half-maximal inhibitory concentration: > 100000 nM
Compound 4: no number, only a limit; the forecaster's own chance of this, stated with the estimate: 10%; middle value at least 6.2-fold (0.79 log units) from the limit.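

Going by these compounds alone, the group on the amide-type nitrogen proves to matter on this core, which the earlier compounds could not show: in this assay, 2-methoxyphenyl in place of 2,5-dimethylphenyl gives an at least 6.4-fold higher number from compound 2 to compound 4 (0.80 log units; beyond the scatter), towards weaker inhibition. Compound 4 stands at a limit of the assay and not at a number, so the full size of this step stays unknown: the limit of > 100000 nM in this assay, at which 2 of the 4 values shown sit.

As far as these compounds go, whether the step follows from losing the methyl groups or from gaining the methoxy stays open. So does how an unsubstituted phenyl or a phenyl carrying a carboxylic acid would read at this place.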